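Swapping the piperidinyl tail for a pyridylmethyl-bearing chain

This account rests on a few compounds, and the source may have more. Where it says the series, first, only, none or still open, it means among the compounds named here.

Compound 1 `c1ccc2c(c1)CN[C@@H](CN(CCCCNC1CCNCC1)[C@H]1CCCc3cccnc31)C2` is one of three close analogues that share a common core and differ only in the group carried on an amine nitrogen at the end of a chain. In a functional assay on cells for antagonist activity at C-X-C chemokine receptor type 4 (Homo sapiens), read by fluorescence and calcium flux, with stated times of 25 min and 90 s (on this read-out higher numbers stand for weaker inhibition and lower numbers for stronger inhibition), compound 1 gives 63.4 nM, which places it second highest of the three numbers recorded. Compound 2 `O=S1(=O)CCC(NCCCCN(C[C@H]2Cc3ccccc3CN2)[C@H]2CCCc3cccnc32)CC1` gives 45.5 nM in this assay, and compound 3 `CC1(C)CCC(NCCCCN(C[C@H]2Cc3ccccc3CN2)[C@H]2CCCc3cccnc32)CC1` gives 77.6 nM. The measured steps are all small: a 1.4-fold lower number from compound 1 to compound 2 (0.14 log units; within the scatter), a 1.2-fold higher number from compound 1 to compound 3 (0.09 log units; within the scatter) and a 1.7-fold higher number from compound 2 to compound 3 (0.23 log units; within the scatter), so no exchange of the terminal ring has so far moved the number beyond the scatter.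

Compound 4 `C(=C/CN(C[C@H]1Cc2ccccc2CN1)[C@H]1CCCc2cccnc21)\CNCc1ccccn1` differs from compound 1 in a different way: a group of 11 heavy atoms (9 carbon, 2 nitrogen; one six-membered aromatic ring with 1 hetero atom) in place of a group of 10 heavy atoms (8 carbon, 2 nitrogen; one six-membered non-aromatic ring with 1 hetero atom), on a saturated chain carbon bound to an amine nitrogen. Among the measured compounds shown here, this change reaches further than the ring swaps already measured, since the chain itself is altered, and none of the measured steps therefore bears on it directly. Given that the three tail variants sit together within the scatter, compound 4 is expected to stay in the same region, with a step of a 1.1-fold higher number from compound 1 to compound 4 (0.04 log units; within the scatter) expected and a wider uncertainty than between the measured pairs. The estimate for compound 4 in this assay is 70 nM, with a range from 20 nM to 250 nM.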

Compound 4, half-maximal inhibitory concentration: 58.3 nM
Compound 4: the middle estimate sits 1.2-fold (0.08 log units) above what was measured, within the range that was stated.
By their numbers in this assay, from the lowest: compounds 2, 4, 1 and 3 (each within the scatter of the next).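

In this assay the exchange gives a 1.1-fold lower number from compound 1 to compound 4 (0.04 log units; within the scatter), so a group with one six-membered aromatic ring with 1 hetero atom and 1 double bond outside aromatic rings leaves the number within the scatter. The earlier steps shown here had exchanged only non-aromatic rings on an amine nitrogen, whereas this one shows that a change on a saturated chain carbon bound to an amine nitrogen, reaching into the chain itself, also produces no step beyond the scatter. Nothing available here explains why the number stays within the scatter.

The aromatic ring and the double bond enter together in compound 4, so their separate contributions cannot be told apart. From the compounds shown here alone, whether a carboxylic acid or an amide at the end of the chain, or a longer chain, would leave the number within the scatter remains open.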